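Ester against amide on the benzyl arm: cytotoxicity notes

The source may report more compounds than this note shows. Statements on the series, on what has been measured and on what is new or still open speak of the compounds shown alone.

compound 1 `CCOC(=O)c1cnc(N2CCN(Cc3cccc(C(=O)OC)c3)CC2)nc1Oc1c(C)cc(-c2ccc(C#N)cc2)cc1C` — > 125000 nM
compound 2 `CCOC(=O)c1cnc(N2CCN(Cc3cccc(C(N)=O)c3)CC2)nc1Oc1c(C)cc(-c2ccc(C#N)cc2)cc1C` — 14800 nM

In an ADME assay on MT4 cells (Homo sapiens) for cytotoxicity, read by MTT assay, with a stated time of 4 days (on this read-out higher numbers stand for lower toxicity in this test and lower numbers for higher toxicity in this test), compound 1 reaches only a limit, > 125000 nM. Among the measured compounds shown here, compound 2 gives 14800 nM in this assay, the only plain number in the set, and the step of an at least 8.4-fold lower number from compound 1 to compound 2 (0.92 log units; beyond the scatter) is bounded by the limit of > 125000 nM in this assay, at which 1 of the 2 values shown sits. Compound 3 `CCOC(=O)c1ccc(CN2CCN(c3ncc(C(=O)OCC)c(Oc4c(C)cc(-c5ccc(C#N)cc5)cc4C)n3)CC2)cc1` differs from compound 2 by 4-(ethoxycarbonyl)phenyl in place of 3-carbamoylphenyl on a saturated chain carbon bound to an amine nitrogen in a ring. This undoes the amide-for-ester change in the opposite direction, so the expected step in this assay is a 6.8-fold higher number from compound 2 to compound 3 (0.83 log units; beyond the scatter), toward the limit. Compound 3 is therefore estimated at 100000 nM, with a range of 30000 nM to 300000 nM.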

Compound 3, half-maximal cytotoxic concentration: > 125000 nM
Compound 3 was reported as a limit; the forecaster's own chance of this, stated with the estimate: 60%; at least 1.2-fold (0.09 log units) between middle value and limit.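

In this assay compound 3 reaches only a limit, > 125000 nM. That bounds an at least 8.4-fold higher number from compound 2 to compound 3 (0.92 log units; beyond the scatter): with 4-(ethoxycarbonyl)phenyl in place of 3-carbamoylphenyl at this place, the number returns to the limit also seen for the ester compound 1, so among these compounds only the amide gives a plain number. The step between compound 1 and compound 3 cannot be read, and the two esters stay unresolved: the limit of > 125000 nM in this assay, at which 2 of the 3 values shown sit.

Open, on these data alone, is whether a carboxylic acid or an amine in place of the carbamoyl group gives a plain number in this assay.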